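Swapping the aryl hydrazone end for a methoxyphenyl

The source may report more compounds than this note shows. Statements on the series, on what has been measured and on what is new or still open speak of the compounds shown alone.

Within the data shown here, compound 2 `O=C(N/N=C/c1ccc(F)c(Br)c1)c1ccc(-c2nc3ccccc3s2)cc1` gives 28000 nM in an assay on isolated protein for inhibition of Maltase-glucoamylase (Homo sapiens), with a stated time of 15 min (on this read-out higher numbers stand for weaker inhibition and lower numbers for stronger inhibition), the higher of the two numbers measured so far. Among the measured compounds shown here, its only measured neighbour is compound 1 `COc1ccc(O)c(/C=N/NC(=O)c2ccc(-c3nc4ccccc4s3)cc2)c1`, which gives 6500 nM; the step of a 4.3-fold higher number from compound 1 to compound 2 (0.63 log units; beyond the scatter) separates them, with 3-bromo-4-fluorophenyl in place of 2-hydroxy-5-methoxyphenyl on a carbon with a double bond to nitrogen. Compound 3 `COc1ccc(/C=N/NC(=O)c2ccc(-c3nc4ccccc4s3)cc2)cc1` differs from compound 2 at the same position: 4-methoxyphenyl in place of 3-bromo-4-fluorophenyl on a carbon with a double bond to nitrogen. For the measured compounds named here, the one measured step that bears on this change is a 4.3-fold higher number from compound 1 to compound 2 (0.63 log units; beyond the scatter), which was modest and beyond the scatter. The 4-methoxyphenyl ring of compound 3 keeps a methoxy group as compound 1 did but lacks a hydroxyl, so a lower number than compound 2 is expected, though not as low as compound 1. Compound 1, with its 6500 nM, and compound 2, with its 28000 nM, are taken to bracket the expectation. The estimate for compound 3 is 12000 nM, between 5000 nM and 35000 nM, which means an expected step of a 2.3-fold lower number from compound 2 to compound 3 (0.37 log units; beyond the scatter).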

Compound 3, half-maximal inhibitory concentration: 18300 nM
Compound 3: middle estimate off by 1.5-fold (0.18 log units), on the low side, and the stated range covers the measured number.
By their numbers in this assay, from the lowest: compound 1; then compounds 3 and 2 (each within the scatter of the next).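

In this assay, the exchange of 3-bromo-4-fluorophenyl for 4-methoxyphenyl on a carbon with a double bond to nitrogen gives a 1.5-fold lower number from compound 2 to compound 3 (0.18 log units; within the scatter), so these two rings cannot be told apart at this position, although the entering group counts a hydrogen-bond acceptor and the leaving group none. Compound 1 stays apart from compound 3, with a 2.8-fold higher number from compound 1 to compound 3 (0.45 log units; beyond the scatter), which shows that a methoxy group on this ring is not enough on its own to reach the number of compound 1, whose 2-hydroxy-5-methoxyphenyl ring gives the lowest number of the three. Nothing measured here offers an explanation for either step.

What the compounds shown leave open is whether the hydroxyl or the different place of the methoxy group carries the step from compound 1 to compound 3, as the two rings differ in both respects. A plain 2-hydroxyphenyl ring would separate these two features, and an amine or a carboxylic acid on this ring would show whether this position accepts anything beyond the groups seen so far.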